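The compounds below may be only part of what the source reports. "The series", "measured", "known", "first", "only" and "open" are said of these compounds alone.

Compound 3 `N=c1sc2cc(OC(F)(F)F)ccc2n1CCO` carries a hydroxy group on a saturated chain carbon, two bonds along the chain from an aromatic nitrogen. In a functional assay on the whole organism with Rattus norvegicus as the target (a lower number here means that less compound is needed, a higher number that more compound is needed for the effect), compound 3 gives 8 mg/kg, the highest of the two numbers in hand, though its nearest neighbour compound 1 `N=c1sc2cc(OC(F)(F)F)ccc2n1CC(N)=O` gives 7 mg/kg, and a 1.1-fold higher number from compound 1 to compound 3 (0.06 log units; within the scatter). Compound 2 `N=c1sc2cc(OC(F)(F)F)ccc2n1CCS(=O)(=O)O` reaches only the limit of this assay, > 10 mg/kg. That gives an at least 1.2-fold lower number from compound 2 to compound 3 (0.09 log units; that floor lies within the scatter) and an at least 1.4-fold higher number from compound 1 to compound 2 (0.15 log units; that floor lies within the scatter), both resting on (the limit of > 10 mg/kg in this assay, at which 1 of the 3 values shown sits).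

Compound 4 `CS(=O)(=O)CCCn1c(=N)sc2cc(OC(F)(F)F)ccc21` differs from compound 3 by (methylsulfonyl)methyl in place of hydroxy on a saturated chain carbon, two bonds along the chain from an aromatic nitrogen. The measured steps that bear on this change all stay within the scatter, with only the sulfo analogue compound 2 sitting at the limit. Compound 4 is therefore expected to give about 9 mg/kg in this assay, within 4 mg/kg to 20 mg/kg, which means the estimated 1.1-fold higher number from compound 3 to compound 4 (0.05 log units; within the scatter) is no step beyond the scatter.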

Compound 4, dose for half-maximal effect: 5 mg/kg
The estimate for compound 4 lay 1.8-fold (0.26 log units) above the measured number, and the stated range covers the measured number.
By their numbers in this assay, from the lowest: compounds 4, 1 and 3 (each within the scatter of the next). At a limit, above all of these: compound 2.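

Moving from hydroxy to (methylsulfonyl)methyl on a saturated chain carbon, two bonds along the chain from an aromatic nitrogen, brings in a larger group with no hydrogen-bond donor, yet in this assay it gives a 1.6-fold lower number from compound 3 to compound 4 (0.20 log units; within the scatter), and the comparison with the carbamoyl side chain gives a 1.4-fold lower number from compound 1 to compound 4 (0.15 log units; within the scatter); a sulfonyl group with no net charge thus leaves the number within the scatter of both earlier neighbours. Compound 2 remains at a limit, > 10 mg/kg. The step to the new compound, an at least 2.0-fold lower number from compound 2 to compound 4 (0.30 log units; that floor lies within the scatter), therefore sets only a floor: the limit of > 10 mg/kg in this assay, at which 1 of the 4 values shown sits.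

As far as these compounds go, whether an amine, a carboxylic acid or a longer chain in this place would produce a step beyond the scatter remains open. So does the effect of any change elsewhere on the shared core.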